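Carbamoyl to methyl on the ring nitrogen: compound 4

The compounds below may be only part of what the source reports. "The series", "measured", "known", "first", "only" and "open" are said of these compounds alone.

Compound 1 `CNC(=O)c1cnc(NC(=O)NC2CCCCC2)n2nc(-c3ccco3)nc12` gives in a functional assay on CHO cells for antagonist activity at adenosine receptor A2b (Homo sapiens); on this read-out higher numbers stand for weaker inhibition and lower numbers for stronger inhibition > 30000 nM, which is a limit of the assay.
Compound 2 `O=C(Nc1ncc(C(=O)O)c2nc(-c3ccco3)nn12)NC1CCCCC1` gives in this assay > 30000 nM, also a limit of the assay.
Compound 3 `CCOC(=O)c1cnc(N2CCCCC2)n2nc(-c3ccco3)nc12` gives in this assay > 10000 nM, likewise a limit of the assay.

Compound 2 thus stands only at a limit in this assay. Among the compounds with values here, all three measured values are limits, two at the limit of > 30000 nM in this assay, at which 2 of the 3 values shown sit, and one at the limit of > 10000 nM in this assay, at which 1 of the 3 values shown sits, so the one measured step from compound 1 to compound 2 is not readable: a step that the two limits leave unreadable from compound 1 to compound 2.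

Compound 4 `CNc1ncc(C(=O)O)c2nc(-c3ccco3)nn12` differs from compound 2 by methyl in place of cyclohexylcarbamoyl on a nitrogen on an aromatic ring. Within the data shown here, no measured step bears on this change, and the limits give no direction. Compound 4 is therefore expected to stay near the same limit, with a step estimated as a number no higher from compound 2 to compound 4 (the limit leaves the size open). For compound 4 an inhibition constant of 30000 nM is estimated, ranging from 3000 nM to 100000 nM.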

Compound 4, inhibition constant: > 10000 nM
Compound 4: a limit, no number; the forecaster's own chance of this, stated with the estimate: 70%; the middle value lies beyond the limit too.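

Compound 2 and compound 4 both stand only at limits in this assay, so the step between them cannot be read. The compounds shown leave open whether methyl or cyclohexylcarbamoyl on a nitrogen on an aromatic ring makes any difference to inhibition.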